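The source may report more compounds than this note shows. Statements on the series, on what has been measured and on what is new or still open speak of the compounds shown alone.

Measured compounds:
- compound 1 `C[C@H](O)[C@@H](CCc1ccc(C(F)(F)F)cc1)n1cnc2c(N)ncnc21`: 5.2 nM in an assay on isolated protein for inhibition of adenosine deaminase (Bos taurus), with a stated time of 5 min; a higher number here means a weaker inhibitor, a lower number a stronger inhibitor
- compound 2 `C[C@H](O)[C@@H](CCc1cccc(C(F)(F)F)c1)n1ccc2c(N)ncnc21`: "not active" (no number reported) in this assay

Among the measured compounds shown here, compound 1 carries the only number in the set; compound 2, which differs from it in more than one place, is reported without a number in this assay, so no step between measured compounds can be drawn. Compound 3 `CC(C)(O)[C@@H](CCc1ccc(C(F)(F)F)cc1)n1cnc2c(N)ncnc21` differs from compound 1 in one place: 1-hydroxy-1-methylethyl in place of 1-hydroxyethyl on a saturated chain carbon bound to an aromatic nitrogen and a saturated chain carbon. With no measured step of this kind in the series, the expectation rests on the value of compound 1 alone, 5.2 nM, and on the small size of the change. The step from compound 1 to compound 3 is expected to be modest and, if anything, toward a weaker inhibitor, a 2.9-fold higher number from compound 1 to compound 3 (0.46 log units; beyond the scatter), though a result within the scatter is also plausible. The estimate for compound 3 is 15 nM, with a range of 3 nM to 80 nM.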

Compound 3, inhibition constant: 69 nM
Beside the measured number, compound 3's estimate is 4.6-fold (0.66 log units) below it; low and high end bracket the measured number.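

In this assay, the position on a saturated chain carbon bound to an aromatic nitrogen and a saturated chain carbon proves sensitive to a small change: 1-hydroxy-1-methylethyl in place of 1-hydroxyethyl gives a 13-fold higher number from compound 1 to compound 3 (1.12 log units; beyond the scatter). Binding is weakened but not lost, as compound 3 still returns a number, 69 nM, so this position tolerates the larger group to a limited degree. The change keeps the hydrogen-bond donor and acceptor counts and removes the defined stereocentre of the 1-hydroxyethyl group, but no measurement shown accounts for the size of this step.

The compounds shown do not separate the effect of the added carbon from that of losing the stereocentre. On these data alone, how the position responds to an amine, a carboxylic acid or a longer hydroxyalkyl chain remains open.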